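Replacing cyclopropyl on the carbonyl carbon of compound 3

The source may report more compounds than this note shows. Statements on the series, on what has been measured and on what is new or still open speak of the compounds shown alone.

Measured in a functional assay on HT-29 cells (Homo sapiens) for inhibition, read by MTT assay, with a stated time of 48 h (a lower number here means a stronger inhibitor, a higher number a weaker inhibitor), so far:
- Compound 1 `COc1cc(-c2nnc(SCc3ccccc3)n2-c2ccc(N(C)C)cc2)cc(OC)c1OC` gives > 60000 nM (a limit)
- Compound 2 `COc1cc(-c2nnc(SCC(=O)c3ccccc3)n2-c2ccc(N(C)C)cc2)cc(OC)c1OC` gives 45200 nM (a measured number)
- Compound 3 `COc1cc(-c2nnc(SCC(=O)C3CC3)n2-c2ccc(N(C)C)cc2)cc(OC)c1OC` gives > 60000 nM (a limit)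

Compound 3 has no exact number and stands at the limit of > 60000 nM in this assay, at which 2 of the 3 values shown sit (the ceiling of the test). Compound 4 `COc1cc(-c2nnc(SCC(=O)Nc3ccc(Cl)cc3)n2-c2ccc(N(C)C)cc2)cc(OC)c1OC` carries (4-chlorophenyl)amino in place of cyclopropyl on a carbonyl carbon and is still unmeasured. The closest guide is an at least 1.3-fold higher number from compound 2 to compound 3 (0.12 log units; that floor lies within the scatter), a change on that same carbon. Also relevant is an at least 1.3-fold lower number from compound 1 to compound 2 (0.12 log units; that floor lies within the scatter) as a second small step. Neither step shows a size beyond the scatter, so only a modest shift is expected. The expected change is an at least 2.0-fold lower number from compound 3 to compound 4 (0.30 log units; that floor lies within the scatter) in this assay as a cautious guess. The estimated value of compound 4 is 30000 nM with a range from 10000 nM to 60000 nM expected.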

Compound 4, half-maximal inhibitory concentration: > 60000 nM
Compound 4 ended at the assay's limit (the forecaster's own chance of this, stated with the estimate: 30%); middle value at least 2.0-fold (0.30 log units) away from the limit.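

Putting (4-chlorophenyl)amino on this carbonyl carbon, with its added hydrogen-bond donor, gives no sign of stronger inhibition, and compound 4 stands at a limit of the test: the limit of > 60000 nM in this assay, at which 3 of the 4 values shown sit. In this assay, for the compounds shown here, the one readable step is an at least 1.3-fold higher number from compound 2 to compound 4 (0.12 log units; that floor lies within the scatter), a floor that stays within the usual scatter. The steps to compound 4 from compound 1 and from compound 3 cannot be read, as both ends of each are limits.

A carboxylic acid or a simple alkylamino group on this carbonyl carbon lies outside the compounds shown, so it stays open whether any group here gives a step beyond the scatter.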